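Fluoro for bromo and methyl for ethyl at the ceiling

The source may report more compounds than this note shows. Statements on the series, on what has been measured and on what is new or still open speak of the compounds shown alone.

Compound 1 `CCn1c(/C=C2/C(=O)Nc3ccc(F)cc32)nc2ccccc21` gives > 50000 nM in a functional assay on 4T1 cells (Homo sapiens) for cytotoxicity, read by MTT assay, with a stated time of 48 h (a lower number here means a stronger inhibitor, a higher number a weaker inhibitor), a limit of the assay rather than a number.
Compound 2 `CCn1c(/C=C2/C(=O)Nc3ccc(Br)cc32)nc2ccccc21` gives 40700 nM in this assay.
Compound 3 `Cn1c(/C=C2/C(=O)Nc3ccc(Br)cc32)nc2ccccc21` gives > 50000 nM in this assay, again a limit and not a number.

Only compound 2 yields a number. The change fluoro in place of bromo on an aromatic carbon produced an at least 1.2-fold higher number from compound 2 to compound 1 (0.08 log units; that floor lies within the scatter), and the change hydrogen in place of methyl on a saturated chain carbon bound to an aromatic nitrogen produced an at least 1.2-fold higher number from compound 2 to compound 3 (0.08 log units; that floor lies within the scatter); both end at a limit, so neither step can be sized beyond its floor, which rests on (the limit of > 50000 nM in this assay, at which 2 of the 3 values shown sit). Compound 4 `Cn1c(/C=C2/C(=O)Nc3ccc(F)cc32)nc2ccccc21` has not been measured. It differs from compound 3 by fluoro in place of bromo on an aromatic carbon, the same change made from compound 2 to compound 1, since the place is described word for word alike; the cores of compound 2 and compound 3 differ by hydrogen in place of methyl on a saturated chain carbon bound to an aromatic nitrogen. Because the limit of > 50000 nM in this assay, at which 2 of the 3 values shown sit, already holds compound 3, the step from compound 3 to compound 4 in this assay is expected to be a step that the limit leaves unreadable from compound 3 to compound 4, with no measurable movement likely. Compound 4 is thus estimated at 90000 nM, within 50000 nM to 250000 nM, and will most probably be reported only as a limit.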

Compound 4, half-maximal inhibitory concentration: 29600 nM
Compound 4: middle estimate off by 3.0-fold (0.48 log units), on the high side, and the stated range ends above it.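

Fluoro in place of bromo on an aromatic carbon gave an at least 1.6-fold lower number from compound 3 to compound 4 (0.22 log units; that floor lies within the scatter), and set beside the earlier step on the other core, this does not show that the change carries over unchanged or that it depends on the core: the same change on two cores in this assay, an at least 1.2-fold higher number (0.08 log units; that floor lies within the scatter) from compound 2 to compound 1 and an at least 1.6-fold lower number (0.22 log units; that floor lies within the scatter) from compound 3 to compound 4; the limit leaves it open whether they differ
Hydrogen in place of methyl on a saturated chain carbon bound to an aromatic nitrogen gave an at least 1.6-fold lower number from compound 1 to compound 4 (0.22 log units; that floor lies within the scatter), and its comparison with the earlier step stays just as unsettled: the same change on two cores in this assay, an at least 1.2-fold higher number (0.08 log units; that floor lies within the scatter) from compound 2 to compound 3 and an at least 1.6-fold lower number (0.22 log units; that floor lies within the scatter) from compound 1 to compound 4; the limit leaves it open whether they differ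
Each of these steps has a limit at one end, so each is known only by its floor, and the true size of neither change can be stated on either core: the limit of > 50000 nM in this assay, at which 2 of the 4 values shown sit.

The compounds shown leave open how chloro or a methoxy group would read in place of bromo in this assay. They also leave open how a longer chain, such as propyl, or a chain ending in an amine would read on the aromatic nitrogen.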